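The compounds below may be only part of what the source reports. "The series", "measured", "known", "first", "only" and "open" are said of these compounds alone.

Compound 1 `N#CC1=C(N)Oc2c(c3nc4ccccc4nc3c3ccccc23)C12C(=O)N(Cc1cnnn1-c1ccc(Cl)cc1)c1ccccc12`, compound 2 `N#CC1=C(N)Oc2c(c3nc4ccccc4nc3c3ccccc23)C12C(=O)N(Cc1cnnn1-c1ccc(N)cc1)c1ccccc12` and compound 3 `N#CC1=C(N)Oc2c(N)cc3nc4ccccc4nc3c2C12C(=O)N(Cc1cnnn1-c1ccc(F)cc1)c1ccccc12` share one core and differ only in the substituent on the phenyl ring attached to the triazole. In a functional assay on MCF7 cells (Homo sapiens) for antiproliferative activity, read by MTT assay, with a stated time of 48 h (on this read-out lower numbers stand for stronger inhibition and higher numbers for weaker inhibition), compound 1 gives only the limit > 50000 nM. Compound 2 gives only the limit > 50000 nM. Compound 3 likewise gives only the limit > 50000 nM. The step that the two limits leave unreadable from compound 1 to compound 2 is unreadable because all three values sit at the limit of > 50000 nM in this assay, at which 3 of the 3 values shown sit. Compound 4 `N#CC1=C(N)Oc2c(N)cc3nc4ccccc4nc3c2C12C(=O)N(Cc1cnnn1-c1cccc(C(F)(F)F)c1)c1ccccc12` differs from compound 3 by 3-(trifluoromethyl)phenyl in place of 4-fluorophenyl on an aromatic nitrogen. Among the compounds with values here, no readable measured step bears on this change, and every value so far is a limit, so no shift beyond the scatter is expected. Compound 4 is expected to give 50000 nM. For compound 4 the expected lower end is 15000 nM and the upper end 150000 nM. The expected step is a number no higher from compound 3 to compound 4 (the limit leaves the size open).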

Compound 4, half-maximal inhibitory concentration: 31600 nM
Compound 4: middle estimate off by 1.6-fold (0.20 log units), on the high side, within the range that was stated.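

The change to 3-(trifluoromethyl)phenyl on the aromatic nitrogen gives an at least 1.5-fold lower number from compound 3 to compound 4 (0.19 log units; that floor lies within the scatter) in this assay. Within the data shown here, compound 4 is the first compound with a measured number rather than a limit, yet the floor of this step does not establish a shift beyond the scatter. The other compounds remain at a limit: the limit of > 50000 nM in this assay, at which 3 of the 4 values shown sit.

Open, going by these compounds, is whether a methoxy group or a carboxylic acid on that phenyl ring would give a step beyond the scatter. Also open, on these data alone, is whether 3-(trifluoromethyl)phenyl gives a measured number on the core of compound 1.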